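The compounds below may be only part of what the source reports. "The series", "measured", "known", "first", "only" and "open" are said of these compounds alone.

The measured compounds:

Compound 1, `Nc1nc(Cl)c2ncn(Cc3ccccc3CCl)c2n1`: 70800 nM
Compound 2, `Nc1nc(Cl)c2ncn(Cc3cccc(CCl)c3)c2n1`: 40700 nM

Both compounds share the same core and were tested in a functional assay on DU-145 cells (Homo sapiens) for cytotoxicity, read by sulforhodamine B assay, with a stated time of 48 h; on this read-out higher numbers stand for lower toxicity in this test and lower numbers for higher toxicity in this test. Compound 1 stands highest of the two numbers; its nearest neighbour is compound 2, whose number is lower, but the gap between them lies within the usual scatter, so the two values show no real difference in this assay.

Compound 3, `ClCc1ccccc1Cn1cnc2c(Cl)ncnc21`, has not yet been measured. Compared with compound 1 it differs in one place: hydrogen in place of amino on an aromatic carbon. Among the measured compounds shown here, no measured pair follows this change, so the size of the step can only be guessed. With no measured precedent among these compounds, the step is expected to be small, most likely staying within the scatter, with no clear direction favoured.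

In this assay compound 3 is therefore expected to give 60000 nM, within a range from 20000 nM to 180000 nM. The estimated step of a 1.2-fold lower number from compound 1 to compound 3 (0.07 log units; within the scatter) is expected to remain within the scatter.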

Compound 3, concentration lethal to 50% of the cells: > 100000 nM
Compound 3 was reported as a limit; the forecaster's own chance of this, stated with the estimate: 10%; middle value at least 1.6-fold (0.22 log units) from the limit.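

Among the compounds shown here, on the aromatic carbon between two ring nitrogen atoms, the earlier compounds both carried amino, so only compound 3 shows what happens when that group is absent. In this assay, compound 3 gives > 100000 nM, which is a limit of the assay and not a number. Hydrogen in place of amino gives an at least 1.4-fold higher number from compound 1 to compound 3 (0.14 log units; that floor lies within the scatter), so the change brings no sign of a lower number, but it cannot be said to raise the number beyond the scatter, and the full size of the step stays unknown because compound 3 is reported only as a limit: the limit of > 100000 nM in this assay, at which 1 of the 3 values shown sits.

The compounds shown leave open how this carbon would read in this assay with a methylamino group, a hydroxyl group or a methoxy group in place of amino, since amino and hydrogen are the only two substituents compared here. They also leave open whether hydrogen in place of amino would give a similar step on the core of compound 2, and whether amino has any real bearing on the number at all.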